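Moving a methoxy group, then swapping it for fluorine

The compounds below may be only part of what the source reports. "The series", "measured", "known", "first", "only" and "open" are said of these compounds alone.

Measured in a functional assay on A549 cells (Homo sapiens) for antiproliferative activity, read by MTT assay, with a stated time of 72 h; a lower number here means a stronger inhibitor, a higher number a weaker inhibitor:
- Compound 1 `COc1ccc(-c2ncnn2-c2cc(OC)c(OC)c(OC)c2)cc1`: 520 nM
- Compound 2 `COc1ccccc1-c1ncnn1-c1cc(OC)c(OC)c(OC)c1`: > 10000 nM, a limit

Compound 2 stands at the limit of > 10000 nM in this assay, at which 1 of the 2 values shown sits, so it has a limit and not a number. Compound 3 `COc1cc(-n2ncnc2-c2ccc(F)cc2)cc(OC)c1OC` differs from it by 4-fluorophenyl in place of 2-methoxyphenyl on an aromatic carbon, with 4-fluorophenyl in place of 2-methoxyphenyl on an aromatic carbon. Going by the values given here, one measured step bears on this: an at least 19-fold higher number from compound 1 to compound 2 (1.28 log units; beyond the scatter), a large change beyond the scatter that brought in the 2-methoxyphenyl which compound 3 gives up. From the compounds shown here alone, a large move to lower numbers in this assay is therefore expected, although 4-fluorophenyl itself is untested. The estimated step is an at least 10-fold lower number from compound 2 to compound 3 (1.00 log units; beyond the scatter). For compound 3 the expected value is 1000 nM, with an estimated range of 150 nM to 6000 nM.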

Compound 3, half-maximal inhibitory concentration: > 10000 nM
Compound 3 gave a limit, no number; the forecaster's own chance of this, stated with the estimate: 12%; at least 10-fold (1.00 log units) between middle value and limit.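

Fluoro in place of methoxy gives an at least 19-fold higher number from compound 1 to compound 3 (1.28 log units; beyond the scatter). So the loss seen with compound 2 is not only a matter of where the methoxy sits: 4-fluorophenyl keeps a group in the place it holds in compound 1, yet the activity still falls away. Compound 3, like compound 2, is a limit and not a number, so the step between them cannot be read: the limit of > 10000 nM in this assay, at which 2 of the 3 values shown sit.

From the compounds shown here alone, only compound 1 gives a number, so it stays open how much of its activity depends on the methoxy itself. A 4-ethoxyphenyl or 4-aminophenyl group in the same place would help to settle that.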